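The source may hold more compounds than are shown below. What is called first, only, known or untested is meant among the compounds shown, and "the series" means these compounds.

The measured compounds, each in a functional assay on FM3A cells (Mus musculus) for inhibition, read by cell counting, with a stated time of 2 days; a higher number here means a weaker inhibitor, a lower number a stronger inhibitor:
compound 1 `C=C(Br)C(=O)Nc1cccc(-c2cn3nc(-c4ccc(OCC)cc4)sc3n2)c1` gives 1100 nM;
compound 2 `Nc1cccc(-c2cn3nc(-c4ccc(F)cc4)sc3n2)c1` gives 33000 nM;
compound 3 `CCc1ccc(-c2nn3cc(-c4cccc(N)c4)nc3s2)cc1` gives 8200 nM.

Among these three, compound 1 stands at the lowest number, with compound 3 nearest to it and compound 2 furthest, and both gaps lie beyond the scatter. Compound 4 `C=C(Br)C(=O)Nc1cccc(-c2cn3nc(-c4ccc(Cl)cc4)sc3n2)c1` differs from compound 1 in a single place: chloro in place of ethoxy on an aromatic carbon.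

Within the data shown here, only one measured step speaks to a change at this position. The step of a 4.0-fold lower number from compound 2 to compound 3 (0.60 log units; beyond the scatter) exchanges a halogen for a larger group on the same ring, and the number fell by a modest amount. Compound 2 and compound 3, however, carry an amine where compound 1 and compound 4 carry the bromoacrylamide, so the comparison is indirect. Read the other way round, a halogen entering for a larger group would be expected to raise the number, and chloro is a heavier halogen than the fluoro of compound 2, which may soften the effect.

Compound 4 is therefore expected to give 3000 nM in this assay, within a range of 1200 nM to 8000 nM, an expected step of a 2.7-fold higher number from compound 1 to compound 4 (0.44 log units; beyond the scatter).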

Compound 4, half-maximal inhibitory concentration: 2000 nM
Beside the measured number, compound 4's estimate is 1.5-fold (0.18 log units) above it, within the range that was stated.
By their numbers in this assay, from the lowest: compounds 1 and 4 (each within the scatter of the next); then compound 3; then compound 2.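

In this assay, replacing the 4-ethoxyphenyl of compound 1 with the 4-chlorophenyl of compound 4 gives a 1.8-fold higher number from compound 1 to compound 4 (0.26 log units; within the scatter), so this pair cannot be told apart in this assay. Among these compounds, the only earlier step at this position, a 4.0-fold lower number from compound 2 to compound 3 (0.60 log units; beyond the scatter), exchanged other groups and did so on compounds carrying an amine in place of the bromoacrylamide, so it said nothing directly about this pair. Among the compounds shown here, the new step adds the first reading with the bromoacrylamide in place: with that group present, ethoxy, with its 3 heavy atoms and 1 hydrogen-bond acceptor, and chloro, with 1 heavy atom and no acceptor, leave the number within the usual scatter.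

Going by these compounds, it remains open whether a hydroxyl, an amine, a carboxylic acid or a chain longer than ethoxy at this place would also keep the number there, and whether fluoro and ethyl would differ with the bromoacrylamide present as they do with the amine. Nothing given here offers an explanation for this result.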